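Triazole aryl swap in a spiro-fused series: compound 3

The source may report more compounds than this note shows. Statements on the series, on what has been measured and on what is new or still open speak of the compounds shown alone.

All members share one core. Compound 1 `N#CC1=C(N)Oc2c(c3nc4ccccc4nc3c3ccccc23)C12C(=O)N(Cc1cnnn1-c1ccc(F)cc1)c1ccccc12` carries 4-fluorophenyl on the triazole nitrogen. In a functional assay on A549 cells (Homo sapiens) for antiproliferative activity, read by MTT assay, with a stated time of 48 h (a higher number here means a weaker inhibitor, a lower number a stronger inhibitor), compound 1 gives only a limit, > 50000 nM. Compound 2 `N#CC1=C(N)Oc2c(c3nc4ccccc4nc3c3ccccc23)C12C(=O)N(Cc1cnnn1-c1ccccc1Br)c1ccccc12` carries 2-bromophenyl in the same place. In this assay compound 2 likewise gives only a limit, > 50000 nM. The step that the two limits leave unreadable from compound 1 to compound 2 is unreadable for that reason, and compound 2 stands together with compound 1 at the limit of > 50000 nM in this assay, at which 2 of the 2 values shown sit; nothing measured separates them.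

Compound 3 `COc1ccc(-n2nncc2CN2C(=O)C3(C(C#N)=C(N)Oc4c3c3nc5ccccc5nc3c3ccccc43)c3ccccc32)cc1` is not yet measured. The change 4-methoxyphenyl in place of 2-bromophenyl on an aromatic nitrogen puts 4-methoxyphenyl in place of 2-bromophenyl on an aromatic nitrogen. Among the measured compounds shown here, the only measured step at this position, from compound 1 to compound 2, gives no size, so no measured step offers a size for the move to compound 3. The expectation for compound 3 is that it again sits at or beyond the limit of this assay, with the expected step that the limit leaves unreadable from compound 2 to compound 3 not beyond the scatter. The estimate for compound 3 is 60000 nM, within 15000 nM to 250000 nM, most likely reported as a limit.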

Compound 3, half-maximal inhibitory concentration: > 50000 nM
Compound 3: a limit, no number (the forecaster's own chance of this, stated with the estimate: 85%); the middle value lies beyond the limit too.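

Compound 3 also gives only a limit in this assay, so no step among compound 1, compound 2 and compound 3 can be read, and all three stand together: the limit of > 50000 nM in this assay, at which 3 of the 3 values shown sit.

The compounds shown leave open whether any aryl group at this triazole nitrogen on the shared core gives a readable value in this assay.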